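Swapping the ring on the sulfonyl chain: compound 4

The source may hold more compounds than are shown below. What is called first, only, known or untested is meant among the compounds shown, and "the series" means these compounds.

Measured so far:
compound 1 `Cc1ccc(C2CNN=C2S(=O)(=O)CC2=NCCS2)cc1`: 39.8%
compound 2 `COc1ccc(C2=NOC(c3ccc(C)cc3)C2S(=O)(=O)CC2=NCCO2)cc1`: 65.9%
compound 3 `Cc1ccc(C2CNN=C2S(=O)(=O)CC2=NCCO2)cc1`: 41.3%

In a functional assay, tested at 50 ug/mL (a higher number here means a stronger effect of the compound at the concentration tested, a lower number a weaker effect), compound 2 gives the highest value of the three, while compound 3 and compound 1 sit close together. Compound 1 and compound 3 differ only by a group of 5 heavy atoms (3 carbon, 1 nitrogen, 1 sulfur; one five-membered non-aromatic ring with 2 hetero atoms) in place of a group of 5 heavy atoms (3 carbon, 1 nitrogen, 1 oxygen; one five-membered non-aromatic ring with 2 hetero atoms), on a saturated chain carbon bound to a sulfonyl sulfur, and that change gave a number 1.5 percentage points lower from compound 3 to compound 1 (within the scatter). Compound 4 `COc1ccc(C2=NOC(c3ccc(C)cc3)C2S(=O)(=O)CC2=NCCS2)cc1` is compound 2 with the same change, (a group of 5 heavy atoms (3 carbon, 1 nitrogen, 1 sulfur; one five-membered non-aromatic ring with 2 hetero atoms) in place of a group of 5 heavy atoms (3 carbon, 1 nitrogen, 1 oxygen; one five-membered non-aromatic ring with 2 hetero atoms), on a saturated chain carbon bound to a sulfonyl sulfur); the place is the same in both pairs. The difference between the core of compound 2 and the core of compound 3 is not broken down here.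

Because a number 1.5 percentage points lower from compound 3 to compound 1 (within the scatter) hardly moved the read-out, the step is expected to be small again, a number 1.9 percentage points lower from compound 2 to compound 4 (within the scatter). In this assay compound 4 is therefore estimated at 64%, expected to lie between 50% and 78%.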

Compound 4, a percentage reported as activity, at one concentration (the size of the read-out at that concentration, not a potency): 47.5%
Estimate against measurement, compound 4: 16.5 percentage points above, outside the stated range (below it).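

Placing the sulfur-containing ring on a saturated chain carbon bound to a sulfonyl sulfur gave, in this assay, a number 18.4 percentage points lower from compound 2 to compound 4 (beyond the scatter). Within the data shown here, the same change therefore does not carry over at the same size between these two cores: the same change on two cores in this assay, a number 1.5 percentage points lower (within the scatter) from compound 3 to compound 1 and a number 18.4 percentage points lower (beyond the scatter) from compound 2 to compound 4, 16.9 percentage points apart, beyond the scatter of two such steps This rests on only one pair for each core, and it shows neither why the two cores respond differently nor how the change would behave on a third core.

The compounds shown leave open how other groups in the same place would compare with the two rings, for example a morpholine ring or a simple amine. They also leave open whether such groups would give the same result on both cores.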